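This account rests on a few compounds, and the source may have more. Where it says the series, first, only, none or still open, it means among the compounds named here.

Measured so far in a functional assay on K562 cells (Homo sapiens) for cytotoxicity, read by trypan blue exclusion, with a stated time of 96 h; a lower number here means a stronger inhibitor, a higher number a weaker inhibitor:
- compound 1 `COc1cc(OC)c(/C=C/S(=O)(=O)Cc2ccc(OC)c(N)c2)c(OC)c1`: 2.5 nM
- compound 2 `COc1cc(OC)c(/C=C/S(=O)(=O)Cc2ccc(OC)c(NC(C(=O)O)c3ccc(Cl)cc3)c2)c(OC)c1`: 250 nM

Compound 2, at 250 nM, has the higher of the two numbers, so it is the weaker inhibitor. Compound 3 `COc1ccc(C(Nc2cc(CS(=O)(=O)/C=C/c3c(OC)cc(OC)cc3OC)ccc2OC)C(=O)O)cc1` is not yet measured. It differs from compound 2 as follows: methoxy in place of chloro on an aromatic carbon. This is methoxy in place of chloro on an aromatic carbon, or 4-chlorophenyl to 4-methoxyphenyl. Among the compounds with values here, the only measured step is large and beyond the scatter: a 100-fold higher number from compound 1 to compound 2 (2.00 log units; beyond the scatter). Within the data shown here, that step adds the whole carboxy(4-chlorophenyl)methyl group, and no measured pair varies the chloro position, so it gives no direct guide to size or direction here. Only a small change is therefore expected in this assay, with no firm direction. The expected step, a 1.1-fold lower number from compound 2 to compound 3 (0.06 log units; within the scatter), lies within the scatter. Compound 3 is estimated at 220 nM, with an expected range of 70 nM to 800 nM.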

Compound 3, half-maximal inhibitory concentration: 15 nM
Compound 3: the middle estimate sits 15-fold (1.17 log units) above what was measured, and the stated range ends above it.
By their numbers in this assay, from the lowest: compound 1; then compound 3; then compound 2.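

In this assay, the substituent para to a large group on the aromatic ring is a sensitive place: the change from 4-chlorophenyl to 4-methoxyphenyl gives a 17-fold lower number from compound 2 to compound 3 (1.22 log units; beyond the scatter). Substitution on the aromatic nitrogen therefore does not carry one fixed cost, since carboxy(4-methoxyphenyl)methyl in place of hydrogen gives only a 6.0-fold higher number from compound 1 to compound 3 (0.78 log units; beyond the scatter), and compound 1, with hydrogen there, keeps the lowest number of the three. Nothing available here accounts for the difference between chloro and methoxy.

Open, as far as these compounds go, is whether other groups at that place, such as hydroxyl, an amine or a longer alkoxy chain, follow methoxy or chloro. Also open, from the compounds shown here alone, is how the carboxylic acid figures in these numbers, as against a methyl ester or a primary amide in its place.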